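The source may hold more compounds than are shown below. What is called first, only, known or untested is meant among the compounds shown, and "the series" means these compounds.

Measured so far:
Compound 1 `O=C(COc1cccc2ccccc12)N/N=C/c1ccccc1[N+](=O)[O-]` — in an ADME assay on MT4 cells (Homo sapiens) for cytotoxicity, read by MTT assay, with a stated time of 4 days (a lower number here means that less compound is tolerated, a higher number that more compound is tolerated), compound 1 gives 12.2 ug/mL
Compound 2 `C/C(=N\NC(=O)COc1cccc2ccccc12)c1ccc(O)cc1O` — in this assay compound 2 gives 59.9 ug/mL

For the measured compounds named here, of the two numbers recorded in this assay, compound 1 stands lowest; the only other compound, compound 2, lies higher by a margin beyond the usual scatter, so compound 1 is the less well tolerated of the pair. Going by the values given here, no single-point step between measured compounds is available, so the two values are all that can be said of them together.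

The next compound, compound 3 `O=C(COc1cccc2ccccc12)N/N=C/c1ccccc1O`, is set against compound 1. The change is hydroxy in place of nitro on an aromatic carbon, on an aromatic carbon of a six-membered aromatic ring of carbon only, ortho to a large group. Compound 3 also shares a hydroxy on its aromatic ring with compound 2, whose value 59.9 ug/mL is the higher of the two measured.

Given the gap between compound 1 at 12.2 ug/mL and compound 2 at 59.9 ug/mL, a rise in tolerated concentration is expected in this assay from compound 1 to compound 3, of moderate size, a 2.6-fold higher number from compound 1 to compound 3 (0.42 log units; beyond the scatter). Compound 3 is therefore estimated at 32 ug/mL, with a range from 12 ug/mL to 85 ug/mL.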

Compound 3, half-maximal cytotoxic concentration: 5.19 ug/mL
Compound 3: the middle estimate sits 6.2-fold (0.79 log units) above what was measured; the whole stated range lies above it.
By their numbers in this assay, from the lowest: compound 3; then compound 1; then compound 2.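

In this assay, for the compounds shown here, hydroxy in place of nitro on an aromatic carbon, ortho to a large group, provides the first step in which only one place changes, a 2.4-fold lower number from compound 1 to compound 3 (0.37 log units; beyond the scatter), so less compound is tolerated with hydroxy than with nitro at this position. Losing the nitro group therefore does not raise the tolerated concentration on this core, and the hydroxy group alone does not bring a number as high as that of the other earlier compound. This rests on a single step at a single position, and no measurement available here explains the fall.

On these data alone, whether other groups at this position, such as an amine, a methoxy group or a carboxylic acid, would lie above or below these two compounds remains open, as does whether hydroxy would give the same step elsewhere on the ring. Compound 2 differs from compound 3 in more than one place, so its higher number cannot be assigned to its second hydroxy, to its methyl group or to any other single feature.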